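Ring-nitrogen substituent swaps in a small series

The source may report more compounds than this note shows. Statements on the series, on what has been measured and on what is new or still open speak of the compounds shown alone.

Of the compounds shown here, two have been measured in a functional assay on CHO cells with adenosine receptor A1 (Homo sapiens) as the target, read by cAMP accumulation and immunoassay, with a stated time of 6 min, tested at 0.1 uM; a lower number here means a stronger effect, a higher number a weaker effect of the compound at the concentration tested. Compound 1 `Nc1scc(CN2CCN(c3ccc([N+](=O)[O-])cc3)CC2)c1C(=O)c1ccc(Cl)cc1` gives -13%. Compound 2 `Nc1scc(CN2CCN(c3cccc(F)c3F)CC2)c1C(=O)c1ccc(Cl)cc1` gives -5.2%, the higher of the two numbers on record; its nearest neighbour is compound 1, and the step of a number 7.8 percentage points higher from compound 1 to compound 2 (within the scatter) lies within the scatter, so the two values cannot be placed in order, and neither compound can be called the more or less active of the pair.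

Compound 3 `Nc1scc(CN2CCN(c3cc(Cl)ccc3Cl)CC2)c1C(=O)c1ccc(Cl)cc1` has not yet been measured. It differs from compound 2 in one place: 2,5-dichlorophenyl in place of 2,3-difluorophenyl on an amine nitrogen in a ring. The step from compound 1 to compound 2 is the only measured one that bears on this change, as it also exchanges the group on an amine nitrogen in a ring, and that step stayed within the scatter. Among the compounds with values here, nothing among the measured values points to a step beyond the scatter here. Compound 3 is therefore expected to give -8%, with a range of -25% to 10%. The step this estimate means, a number 2.8 percentage points lower from compound 2 to compound 3 (within the scatter), is expected to lie within the scatter.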

Compound 3, a percentage reported as activity, at one concentration (the size of the read-out at that concentration, not a potency): -6.2%
Compound 3: middle estimate off by 1.8 percentage points, on the low side; low and high end bracket the measured number.
By their numbers in this assay, from the lowest: compounds 1, 3 and 2 (each within the scatter of the next).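

In this assay, 2,5-dichlorophenyl in place of 2,3-difluorophenyl on an amine nitrogen in a ring gives a number 1 percentage points lower from compound 2 to compound 3 (within the scatter), and 2,5-dichlorophenyl in place of 4-nitrophenyl at the same place gives a number 6.8 percentage points higher from compound 1 to compound 3 (within the scatter). The position now carries three different substituted phenyl groups, and all three steps among them lie within the scatter, so no group can be placed ahead of another; this includes the exchange of two fluorine for two chlorine at an equal count of heavy atoms, with the substitution pattern on the ring changing as well. No supporting measurement is available to account for these values.

As far as these compounds go, all three groups on this nitrogen are six-membered aromatic rings of carbon only, so it remains open whether a group of another kind there, such as a longer alkyl chain, an amide or a carboxylic acid, would give a step beyond the scatter. Each value is also a read-out at a single concentration, so the series offers no potency for any of the three compounds.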